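The source may report more compounds than this note shows. Statements on the series, on what has been measured and on what is new or still open speak of the compounds shown alone.

Compound 1 `COc1cccc(OC)c1C(=O)Nc1nnc(-c2ccccc2)s1` carries hydrogen where compound 2 carries tert-butyl; in a functional assay on the whole organism (integument) for inhibition, with Chilo suppressalis as the target, read by scintillation counting, with a stated time of 72 h, in the presence of a further agent that is not named here (a lower number here means a stronger inhibitor, a higher number a weaker inhibitor), compound 1 gives 282 nM. Compound 2 `COc1cccc(OC)c1C(=O)Nc1nnc(-c2ccc(C(C)(C)C)cc2)s1` carries tert-butyl on the outer ring, and in this assay compound 2 gives 525 nM, the highest of the three numbers, although its steps to both other compounds remain within the scatter. Compound 3 `COc1cccc(OC)c1C(=O)Nc1nnc(-c2ccc([N+](=O)[O-])cc2)s1` carries nitro at the same place; in this assay compound 3 gives 269 nM. Compound 4 `CCOc1ccc(-c2nnc(NC(=O)c3c(OC)cccc3OC)s2)cc1` differs from compound 2 by ethoxy in place of tert-butyl on an aromatic carbon. Among the measured compounds shown here, two measured steps concern an exchange at this position: a 1.9-fold higher number from compound 1 to compound 2 (0.27 log units; within the scatter) and a 2.0-fold lower number from compound 2 to compound 3 (0.29 log units; within the scatter), neither beyond the scatter, and the remaining comparison, a 1.0-fold lower number from compound 1 to compound 3 (0.02 log units; within the scatter), is likewise flat. Three different groups at this place thus give numbers that cannot be told apart, so putting a fourth group there is expected to change little in this assay, with no step beyond the scatter in either direction. The step from compound 2 to compound 4 is expected to be a 1.6-fold lower number from compound 2 to compound 4 (0.20 log units; within the scatter). For compound 4 the estimate in this assay is 330 nM, with a range from 150 nM to 750 nM.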

Compound 4, half-maximal inhibitory concentration: 95.5 nM
For compound 4 the middle estimate is 3.5-fold (0.54 log units) above the measured one; measured number below the stated range.
By their numbers in this assay, from the lowest: compound 4; then compounds 3, 1 and 2 (each within the scatter of the next).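

In this assay, among the compounds shown here, this position is not as flat as the earlier compounds suggested: ethoxy gives a 5.5-fold lower number from compound 2 to compound 4 (0.74 log units; beyond the scatter), along with a 2.8-fold lower number from compound 3 to compound 4 (0.45 log units; beyond the scatter) and a 3.0-fold lower number from compound 1 to compound 4 (0.47 log units; beyond the scatter). For the compounds shown here, all three steps lie beyond the scatter, though they are modest, so compound 4 is the strongest inhibitor of the four and ethoxy is the only one of the four groups that separates from the others at this place. No available evidence explains this difference, and the role of the ether oxygen in ethoxy remains unassigned.

A single ether leaves open whether the lower number belongs to ethoxy alone or extends to related groups such as methoxy or a longer propoxy chain. A hydroxyl or an amine at the same place would show whether an oxygen-linked alkyl chain is needed at all.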